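Swapping Fluoro for Methoxy on a Shared Core

The source may report more compounds than this note shows. Statements on the series, on what has been measured and on what is new or still open speak of the compounds shown alone.

For the measured compounds named here, compound 2 `CCOC(=O)c1sc(-c2ccncc2)nc1N1CCC(NCc2ccc(F)cc2)CC1` was tested in an ADME assay on RAW264.7 cells (Mus musculus) for cytotoxicity, read by MTT assay, with a stated time of 72 h, tested at 50 uM (a higher number here means more inhibition at the concentration tested (going by the name of the read-out), a lower number less inhibition), and gives 17.5%, the higher of the two numbers known so far. Compound 1 `CCOC(=O)c1sc(-c2ccccn2)nc1N1CCC(NCc2ccc(OC)cc2)CC1`, which differs from it in two places, gives 4.62% in this assay, a gap beyond the usual scatter. Compound 3 `CCOC(=O)c1sc(-c2ccncc2)nc1N1CCC(NCc2ccc(OC)cc2)CC1` has not been measured; it differs from compound 2 by methoxy in place of fluoro on an aromatic carbon. With no single-change comparison to lean on, the step of a number 6.5 percentage points lower from compound 2 to compound 3 (within the scatter) is expected to be small, at most a modest fall and possibly none beyond the scatter. Compound 3 is therefore estimated at 11%, within 0% to 25%.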

Compound 3, a percentage reported as inhibition, at one concentration (the size of the read-out at that concentration, not a potency): 16.1%
The estimate for compound 3 lay 5.1 percentage points below the measured number; the range from low to high includes it.
By their numbers in this assay, from the lowest: compound 1; then compounds 3 and 2 (each within the scatter of the next).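

In this assay, methoxy and fluoro on the benzyl ring cannot be told apart, with a number 1.4 percentage points lower from compound 2 to compound 3 (within the scatter) as the step for this change. The pyridine change does separate two compounds, with a number 11.5 percentage points higher from compound 1 to compound 3 (beyond the scatter) for pyridin-4-yl in place of pyridin-2-yl, so of these two single changes only the pyridine one reaches beyond the scatter. No measurement here explains either step. Still open, on these data alone, is whether an amine or a carboxylic acid in the same place on the benzyl ring would also leave the number within the scatter. As far as these compounds go, how a pyridin-3-yl group would compare also remains open.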